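The source may hold more compounds than are shown below. What is called first, only, known or untested is meant among the compounds shown, and "the series" means these compounds.

Measured compounds:
compound 1, `CCc1cc(Nc2nc(N[C@@H](C)c3ccc(F)cc3)nc3ccc(F)cc23)n[nH]1`, 160 nM
compound 2, `CCc1cc(Nc2nc(N[C@@H](C)c3ccc(F)cc3)nc3cccc(F)c23)n[nH]1`, 41 nM
compound 3, `CCc1cc(Nc2nc(NCc3ccc(F)cc3)nc3ccccc23)n[nH]1`, 250 nM

In an assay on isolated protein for inhibition of G protein-coupled receptor kinase 6 (Homo sapiens), read by scintillation counting, radiometric assay and 33P incorporation, with a stated time of 80 min, in the presence of a further agent that is not named here (on this read-out lower numbers stand for stronger inhibition and higher numbers for weaker inhibition), compound 3 gives the highest number of the three. Its nearest neighbour is compound 1, whose value lies within the scatter of that of compound 3, so the two cannot be ordered. Compound 2 stands clearly apart with a lower number, beyond the scatter. Among the measured compounds shown here, compounds 1 and 2 differ from compound 3 in more than one place, so no single step between measured compounds is available.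

Compound 4, `CCc1cc(Nc2nc(N[C@H](C)c3ccc(F)cc3)nc3ccccc23)n[nH]1`, is not yet measured. It differs from compound 3 in one place: methyl in place of hydrogen on a saturated chain carbon bound to an aromatic carbon and a nitrogen on an aromatic ring. Compounds 1 and 2 also carry a methyl at this position, but they differ further from compound 3, so their values show nothing clean about the change itself.

No measured pair mirrors this change, so there is no shown step on which a direction could rest. The expected step of a 1.2-fold higher number from compound 3 to compound 4 (0.08 log units; within the scatter) is small, within the scatter, with no clear direction. Compound 4 is therefore estimated at 300 nM, within a range from 100 nM to 1000 nM.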

Compound 4, half-maximal inhibitory concentration: 1400 nM
For compound 4 the middle estimate is 4.7-fold (0.67 log units) below the measured one; measured number above the stated range.
By their numbers in this assay, from the lowest: compound 2; then compounds 1 and 3 (each within the scatter of the next); then compound 4.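

In this assay the change from 4-fluorobenzyl to 1-(4-fluorophenyl)ethyl gives a clear loss of inhibition (a 5.6-fold higher number from compound 3 to compound 4 (0.75 log units; beyond the scatter)), so this saturated chain carbon does not tolerate every added methyl. Among the compounds shown here, compounds 1 and 2 carry a methyl here too, but their further differences from compound 3 hid what the methyl alone does, and this pair is the only clean reading of the change. It is a single pair on a single core, so it supports no general rule for this position, and nothing given here explains the size or direction of the step.

As far as these compounds go, compound 4 has the methyl drawn in the opposite spatial arrangement to that in compounds 1 and 2, so it remains open whether the arrangement found in those two would give a similar step on the core of compound 3. Also open, from the compounds shown here alone, is how this carbon would respond to an ethyl, a hydroxymethyl or a second methyl, and whether the step would hold on the fluorinated cores of compounds 1 and 2.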